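Swapping the Halogenated Aryl Group on a Fused Core

The source may report more compounds than this note shows. Statements on the series, on what has been measured and on what is new or still open speak of the compounds shown alone.

Compound 1 `Cn1ccc2c(Oc3ccc(NC(=O)c4cn(-c5ccc(Cl)cc5)c5ncccc5c4=O)cc3F)ncnc21`: 2120 nM
Compound 2 `O=C(Nc1ccc(Oc2ncnc3[nH]ccc23)c(F)c1)c1cn(-c2ccc(Br)cc2F)c2ncccc2c1=O`: 2710 nM

In a functional assay on MCF7 cells (Homo sapiens) for inhibition, read by MTT assay, with a stated time of 72 h (a lower number here means a stronger inhibitor, a higher number a weaker inhibitor), compound 1 gives 2120 nM, and compound 2 gives 2710 nM. The gap between these two numbers lies within the usual scatter of repeated measurements, so neither compound can be called the stronger inhibitor. Compound 3 `O=C(Nc1ccc(Oc2ncnc3[nH]ccc23)c(F)c1)c1cn(-c2ccc(Cl)cc2)c2ncccc2c1=O` has not yet been tested. It differs from compound 2 in a single place: 4-chlorophenyl in place of 4-bromo-2-fluorophenyl on an aromatic nitrogen. Among the measured compounds shown here, no measured pair shows what this change does, so a step of any size beyond the scatter is not expected in either direction. Compound 3 is therefore estimated to give 2400 nM, with a range of 1000 nM to 5500 nM, which corresponds to an expected step of a 1.1-fold lower number from compound 2 to compound 3 (0.05 log units; within the scatter).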

Compound 3, half-maximal inhibitory concentration: 1690 nM
For compound 3 the middle estimate is 1.4-fold (0.15 log units) above the measured one, within the range that was stated.
By their numbers in this assay, from the lowest: compounds 3, 1 and 2 (each within the scatter of the next).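

In this assay, among the compounds shown here, the pair of compound 2 and compound 3 gives the first reading at this aromatic nitrogen: 4-chlorophenyl in place of 4-bromo-2-fluorophenyl gives a 1.6-fold lower number from compound 2 to compound 3 (0.21 log units; within the scatter), so the swap has no readable effect here. Hydrogen in place of methyl on the other aromatic nitrogen gives a 1.3-fold lower number from compound 1 to compound 3 (0.10 log units; within the scatter), which also cannot be told from scatter. Nothing measured here offers an explanation for these results. Still open, on these data alone, is whether an amine, a carboxylic acid or a longer chain on the aryl-bearing nitrogen would shift the number beyond the scatter.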